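The source may hold more compounds than are shown below. What is called first, only, known or untested is meant among the compounds shown, and "the series" means these compounds.

Of the compounds shown here, three sharing one core have been measured in a functional assay on HT-29 cells (Homo sapiens) for antiproliferative activity, read by sulforhodamine B assay, with a stated time of 48 h (on this read-out higher numbers stand for weaker inhibition and lower numbers for stronger inhibition), so far. Compound 1 (`CCc1ccccc1NS(=O)(=O)c1ccc(N2CCNC2=O)cc1`) gives 240 nM in this test, compound 2 (`O=C1NCCN1c1ccc(S(=O)(=O)Nc2ccc(F)cc2)cc1`) gives 370 nM and compound 3 (`CCc1ccc(NS(=O)(=O)c2ccc(N3CCNC3=O)cc2)cc1`) gives 660 nM on the same scale. Compound 3 therefore stands clear of compound 1 on the weaker side, but it cannot be told apart from compound 2.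

The next compound, compound 4 (`O=C1NCCN1c1ccc(S(=O)(=O)Nc2ccccc2)cc1`), simply loses the ethyl group of compound 3, with hydrogen in place of ethyl on an aromatic carbon, so that 4-ethylphenyl becomes phenyl (hydrogen in place of ethyl on an aromatic carbon).

Going by the values given here, no measured step makes exactly this change. The closest guide is a 1.8-fold higher number from compound 2 to compound 3 (0.25 log units; within the scatter) and it exchanges fluoro for ethyl at that same place on the ring. A second small change of the sulfonamide group is a 1.5-fold higher number from compound 1 to compound 2 (0.19 log units; within the scatter) and it tells the same story. Among the compounds with values here, the one clear step is a 2.8-fold higher number from compound 1 to compound 3 (0.44 log units; beyond the scatter) but it concerns where the ethyl sits, not whether it is present.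

With only these steps to go on, little change is expected, and the expected 1.2-fold lower number from compound 3 to compound 4 (0.08 log units; within the scatter) is no more than an estimate. For compound 4 the estimated value is 550 nM with an expected range from 250 nM to 1300 nM in this test.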

Compound 4, half-maximal inhibitory concentration: 280 nM
Estimate against measurement, compound 4: 2.0-fold (0.29 log units) above; the measured number falls inside the stated range.
By their numbers in this assay, from the lowest: compounds 1, 4, 2 and 3 (each within the scatter of the next, the first and the last beyond it).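

Taking the ethyl group away shows for the first time what this position does with only hydrogen on it: in this assay the change from 4-ethylphenyl to phenyl gives a 2.4-fold lower number from compound 3 to compound 4 (0.37 log units; beyond the scatter) and so, although the shift is modest, an ethyl group para to a large group goes with weaker inhibition than hydrogen does. Fluoro at the same place behaves differently, since a 1.3-fold lower number from compound 2 to compound 4 (0.12 log units; within the scatter) and so hydrogen and fluoro cannot be told apart in this test. The plain phenyl also cannot be separated from the 2-ethylphenyl group, with a 1.2-fold higher number from compound 1 to compound 4 (0.07 log units; within the scatter) as the step, so among these four compounds only the 4-ethylphenyl group stands clear of any other, and then only from phenyl and 2-ethylphenyl, as its step from fluoro stays within the scatter.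

Still open, on these data alone, is whether the loss grows with a longer chain such as propyl at this place, and whether a methoxy group, an amine or a carboxylic acid there would move the number in either direction. The data shown include no independent measurement that could explain why the ethyl group matters at this position.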